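A few compounds are considered here, and "the series" means these few. Any claim that something is new, unique, unknown or untested is made for them only; others in the source may bear on it.

Working notes on the series. Among the compounds with values here, compound 3 `COc1cc(-n2cccc2C(=O)NCCO)ccc1Nc1ncc(Cl)c(Nc2ccccc2NS(C)(=O)=O)n1` stands lowest of the three numbers so far: in a functional assay on KARPAS-299 cells (Homo sapiens) for antiproliferative activity, read by MTT assay, with a stated time of 4 h (a higher number here means a weaker inhibitor, a lower number a stronger inhibitor), compound 3 gives 45 nM. Compound 1 `COc1cc(-n2cccc2C(=O)N2CCCCC2)ccc1Nc1ncc(Cl)c(Nc2ccccc2NS(C)(=O)=O)n1` gives 1040 nM in this assay, and compound 2 `CCN1CCN(C(=O)c2cccn2-c2ccc(Nc3ncc(Cl)c(Nc4ccccc4NS(C)(=O)=O)n3)c(OC)c2)CC1` gives 1410 nM; the step of a 1.4-fold higher number from compound 1 to compound 2 (0.13 log units; within the scatter) is within the scatter, so those two are not ordered against each other. The two steps onto compound 3 are large in the same direction: a 23-fold lower number from compound 1 to compound 3 (1.36 log units; beyond the scatter) and a 31-fold lower number from compound 2 to compound 3 (1.50 log units; beyond the scatter).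

Compound 4 `COc1cc(-n2cccc2C(=O)N(C)C)ccc1Nc1ncc(Cl)c(Nc2ccccc2NS(C)(=O)=O)n1` is not yet measured. It differs from compound 3 by dimethylamino in place of (2-hydroxyethyl)amino on a carbonyl carbon. Within the data shown here, no measured pair has this exact change, so the bearing steps are the two just named, each removing a group on the carbonyl carbon in favour of (2-hydroxyethyl)amino and lowering the number markedly. Compound 4 takes (2-hydroxyethyl)amino away again, so the number is expected to go back up, beyond the scatter; whether as far as with piperidin-1-yl or 4-ethylpiperazin-1-yl is not settled by these data. The expected step is a 10-fold higher number from compound 3 to compound 4 (1.00 log units; beyond the scatter). Compound 4 is estimated at 450 nM, with a range of 120 nM to 1600 nM.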

Compound 4, half-maximal inhibitory concentration: 780 nM
Compound 4: middle estimate off by 1.7-fold (0.24 log units), on the low side; the range from low to high includes it.
By their numbers in this assay, from the lowest: compound 3; then compounds 4, 1 and 2 (each within the scatter of the next).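

Compound 3 loses its low number in this assay even when the replacement on the carbonyl carbon is a small group with no ring, a 17-fold higher number from compound 3 to compound 4 (1.24 log units; beyond the scatter). Dimethylamino also falls in with the two ring-bearing amines, a 1.8-fold lower number from compound 2 to compound 4 (0.26 log units; within the scatter) and a 1.3-fold lower number from compound 1 to compound 4 (0.12 log units; within the scatter), both within the scatter, so compounds 1, 2 and 4 are not ordered among themselves and, of the groups shown, only (2-hydroxyethyl)amino stands apart. No measurement at hand accounts for this separation.

The change to compound 4 removes the hydroxyl and the amide hydrogen together, so the compounds shown leave open which of them goes with the low number. Ethylamino, which keeps the amide hydrogen without the hydroxyl, and a longer chain such as (3-hydroxypropyl)amino remain open on this carbonyl carbon.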